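The source may hold more compounds than are shown below. What is called first, only, known or untested is meant among the compounds shown, and "the series" means these compounds.

Three peptide-like compounds sharing one core have been examined in an ADME assay for permeability, using PAMPA; on this read-out lower numbers stand for lower permeability and higher numbers for higher permeability. Compound 1, `CCCC[C@H](NC(=O)[C@H](CCCCN)NC(=O)[C@H](CCCNC(=N)N)NC(=O)c1ccc(/C=C2\SC(=O)N(c3ccc(C)cc3)C2=O)cc1)C(N)=O`, gives 0.66 10^-6 cm/s in this assay. Compound 2, `CCCC[C@H](NC(=O)[C@H](CCCN)NC(=O)[C@H](CCCNC(=N)N)NC(=O)c1ccc(/C=C2\SC(=O)N(Cc3ccccc3)C2=O)cc1)C(N)=O`, is reported in this assay only as "impermeable" (no number reported), with no number attached. Compound 3, `CCCC[C@H](NC(=O)[C@H](CCCCN)NC(=O)[C@H](CCCNC(=N)N)NC(=O)c1ccc(/C=C2\SC(=S)N(Cc3ccc(OC)cc3)C2=O)cc1)C(N)=O`, gives 0.6 10^-6 cm/s in this assay, and this number and that of compound 1 lie within the scatter of each other, so the two cannot be ranked against one another; compound 2, lacking a number, stands apart from both.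

The step of interest leads from compound 3 to compound 4, `C=CCN1C(=O)/C(=C/c2ccc(C(=O)N[C@@H](CCCNC(=N)N)C(=O)N[C@@H](CCCCN)C(=O)N[C@@H](CCCC)C(N)=O)cc2)SC1=S`. The change is vinyl in place of 4-methoxyphenyl on a saturated chain carbon bound to an amide-type nitrogen in a ring. Within the data shown here, no measured pair differing at this one place exists among the three compounds, so the size of this step cannot be read from a neighbouring step and must be judged from the spread of the numbers already seen.

Because compound 1 at 0.66 10^-6 cm/s and compound 3 at 0.6 10^-6 cm/s sit close together despite different groups at the ring nitrogen, the author expects compound 4 to stay in the same low region, with the step of a 1.3-fold lower number from compound 3 to compound 4 (0.12 log units; within the scatter) expected to be small and, if anything, downward, not clearly beyond the scatter. The estimate for compound 4 is 0.45 10^-6 cm/s, with a range from 0.15 10^-6 cm/s to 1 10^-6 cm/s.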

Compound 4, apparent permeability: 0.42 10^-6 cm/s
Compound 4: the middle estimate sits 1.1-fold (0.03 log units) above what was measured; the measured number falls inside the stated range.
By their numbers in this assay, from the lowest: compounds 4, 3 and 1 (each within the scatter of the next).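

Among these compounds, this change gives the first measured step at this position: in this assay the exchange of 4-methoxyphenyl for vinyl on a saturated chain carbon bound to an amide-type nitrogen in a ring gives a 1.4-fold lower number from compound 3 to compound 4 (0.15 log units; within the scatter). The exchange removes a six-membered aromatic ring of carbon only and a hydrogen-bond acceptor, and cut one bond further out it reads 4-methoxybenzyl to allyl, yet the step does not go beyond the usual scatter of the read-out. For this one pair, then, a large difference in the size of the group is not matched by a difference that can be resolved in this assay, and nothing measured here accounts for that outcome.

Going by these compounds, a single pair cannot show whether this position tolerates other kinds of group, so it remains open whether a primary amine, a carboxylic acid or a longer chain such as n-hexyl at this place would give a step beyond the scatter. On these data alone, it also remains open whether the 4-methoxyphenyl to vinyl exchange would give a similar step on a different peptide chain or with a carbonyl in place of the thiocarbonyl in the shared core.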